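A Heteroaryl Ring Replaces the Phenyl Amide

A few compounds are considered here, and "the series" means these few. Any claim that something is new, unique, unknown or untested is made for them only; others in the source may bear on it.

Compound 2 `CCc1ccc(C(=O)Nc2cccc(NC(=O)COc3ccc4c(=O)ccoc4c3)c2)cc1` gives 235 nM in an assay on isolated protein for inhibition of Rho-associated protein kinase 1 (Homo sapiens), read by scintillation counting, radiometric assay and 33P incorporation, with a stated time of 40 min, in the presence of a further agent that is not named here (on this read-out lower numbers stand for stronger inhibition and higher numbers for weaker inhibition), the only plain number among the two results shown. Compound 1 `COc1cccc(OCC(=O)Nc2cccc(NC(=O)c3ccc(N(C)C)cc3)c2)c1` reaches only the assay limit of > 10000 nM in this assay. Within the data shown here, compound 3 `Cc1cc(C(=O)Nc2cccc(NC(=O)COc3ccc4c(=O)ccoc4c3)c2)no1` differs from compound 2 in one place: 5-methyl-1,2-oxazol-3-yl in place of 4-ethylphenyl on a carbonyl carbon No measured pair shares this change, so the size of the step rests on judgement alone. The step of a 3.4-fold higher number from compound 2 to compound 3 (0.53 log units; beyond the scatter) is expected to be modest, toward weaker inhibition. Compound 3 is therefore estimated at 800 nM, with a likely range from 200 nM to 4000 nM.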

Compound 3, half-maximal inhibitory concentration: 68 nM
Estimate against measurement, compound 3: 12-fold (1.07 log units) above; the measured number lies below the stated range.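

At this carbonyl carbon, a six-membered ring of carbon only is not required: 5-methyl-1,2-oxazol-3-yl in place of 4-ethylphenyl, a smaller five-membered aromatic ring with hetero atoms, brings a 3.5-fold lower number from compound 2 to compound 3 (0.54 log units; beyond the scatter) in this assay. Inhibition therefore grows stronger with this swap of rings, in the one pair available. Nothing shown accounts for this step. As far as these compounds go, whether the gain follows the hetero atoms or the smaller size remains open. So does the effect of replacing the methyl on this ring with an ethyl or an amine.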